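From Isobutyl to Trifluoromethyl on a Shared Core

The source may hold more compounds than are shown below. What is called first, only, known or untested is meant among the compounds shown, and "the series" means these compounds.

Values in an ADME assay for permeability, using PAMPA, at pH 5.5; a lower number here means that the compound crosses the layer more slowly, a higher number that the compound crosses the layer faster
- compound 1 `CC(C)Cc1ccc(-c2cn(C)c3cc(C(=O)NS(C)(=O)=O)ccc23)cc1` gives "not determined" (no result reported)
- compound 2 `CC(C)COc1ncc(-c2nn(C)c3cc(C(=O)NS(C)(=O)=O)ccc23)cc1Cl` gives 1160 nm/s

Compound 1 has no number in this assay, so it offers no fixed point from which to count a step. Compound 3 `Cn1cc(-c2ccc(C(F)(F)F)cc2)c2ccc(C(=O)NS(C)(=O)=O)cc21` comes from compound 1 by a single exchange, trifluoromethyl in place of isobutyl on an aromatic carbon, para to a large group (trifluoromethyl in place of isobutyl on an aromatic carbon). Among the compounds with values here, no measured pair in this small set shows what such an exchange does. A step beyond the usual scatter, in either direction, is therefore not expected. Within the data shown here, the only available anchor is compound 2 (1160 nm/s), and the expectation leans on that single value, with a slight allowance downward. Compound 3 is expected to read about 800 nm/s with an estimated range from 300 nm/s to 1900 nm/s in this assay once measured.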

Compound 3, apparent permeability: 972 nm/s
Compound 3: the middle estimate sits 1.2-fold (0.08 log units) below what was measured; the measured number falls inside the stated range.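

In this assay, within the data shown here, compound 1 gives "not determined" (no result reported) and so no step from it to compound 3 can be read. As far as these compounds go, what trifluoromethyl in place of isobutyl does on this shared core stays open, and no other data on hand bear on this result.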